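A few compounds are considered here, and "the series" means these few. Any claim that something is new, unique, unknown or untested is made for them only; others in the source may bear on it.

Working notes on the series. In a functional assay on HCT-116 cells (Homo sapiens) for antiproliferative activity, read by MTT assay, with a stated time of 72 h (on this read-out lower numbers stand for stronger inhibition and higher numbers for weaker inhibition), compound 1 `O=C1COc2ccc(-c3cnc(Cl)c(NS(=O)(=O)c4ccc(F)cc4)c3)cc2N1c1ccc(F)cc1` gives 34200 nM; compound 2 `O=C1COc2ccc(-c3cnc(Cl)c(NS(=O)(=O)c4ccc(F)cc4)c3)cc2N1c1ccc(Cl)cc1` gives 27900 nM; compound 3 `COc1ncc(-c2ccc3c(c2)N(c2ccc(Cl)cc2)C(=O)CO3)cc1NS(=O)(=O)c1ccc(F)cc1` gives 19200 nM. The number for compound 2 sits between the other two, separated from them by a 1.2-fold lower number from compound 1 to compound 2 (0.09 log units; within the scatter) and by a 1.5-fold lower number from compound 2 to compound 3 (0.16 log units; within the scatter), both within the scatter. Compound 4 `COc1ccc(N2C(=O)COc3ccc(-c4cnc(Cl)c(NS(=O)(=O)c5ccc(F)cc5)c4)cc32)cc1` carries, relative to compound 2, (methoxy in place of chloro on an aromatic carbon). Among the compounds with values here, two measured steps bear on this: a 1.2-fold lower number from compound 1 to compound 2 (0.09 log units; within the scatter), which touched the same aromatic carbon, and a 1.5-fold lower number from compound 2 to compound 3 (0.16 log units; within the scatter), the same exchange of groups on another aromatic carbon; neither moved beyond the scatter. The expected step is therefore a 1.1-fold lower number from compound 2 to compound 4 (0.05 log units; within the scatter), none beyond the scatter. Compound 4 is estimated at 25000 nM, with a range of 10000 nM to 60000 nM.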

Compound 4, half-maximal inhibitory concentration: 30100 nM
Estimate against measurement, compound 4: 1.2-fold (0.08 log units) below; low and high end bracket the measured number.
By their numbers in this assay, from the lowest: compounds 3, 2, 4 and 1 (each within the scatter of the next).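

In this assay, the change from 4-chlorophenyl to 4-methoxyphenyl gives a 1.1-fold higher number from compound 2 to compound 4 (0.03 log units; within the scatter), and methoxy in place of fluoro on the same aromatic carbon gives a 1.1-fold lower number from compound 1 to compound 4 (0.06 log units; within the scatter). This carbon has now carried fluoro, chloro and methoxy with no step beyond the scatter, so a group with a hydrogen-bond acceptor and one more heavy atom leaves the number unmoved here, as the same exchange did on another aromatic carbon. No available data explain this flat response. As far as these compounds go, whether an amine or a carboxylic acid on this carbon would move the number beyond the scatter remains open.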